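A methoxy neighbour for the chlorine: an untested half-life

The compounds below may be only part of what the source reports. "The series", "measured", "known", "first", "only" and "open" are said of these compounds alone.

Measured so far in an ADME assay on microsomes from liver (Rattus norvegicus) for metabolic stability; on this read-out lower numbers stand for a shorter-lived compound and higher numbers for a longer-lived compound:
Compound 1 `Nc1nc(NCCNc2ncc(-c3ncc[nH]3)c(-c3ccccc3Cl)n2)ccc1[N+](=O)[O-]` gives > 0.5 h, a limit of the assay.
Compound 2 `Nc1nc(NCCNc2ncc(-c3ncc[nH]3)c(-c3ccc(F)cc3C(F)(F)F)n2)ccc1[N+](=O)[O-]` gives > 0.5 h, a limit of the assay.
Compound 3 `Nc1nc(NCCNc2ncc(-c3ncc[nH]3)c(-c3ccc(Br)cc3Cl)n2)ccc1[N+](=O)[O-]` gives > 0.5 h, a limit of the assay.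

Compound 1 thus stands only at a limit in this assay, and every other value shown sits at the same place: the limit of > 0.5 h in this assay, at which 3 of the 3 values shown sit. Compound 4 `COc1cc(Cl)ccc1-c1nc(NCCNc2ccc([N+](=O)[O-])c(N)n2)ncc1-c1ncc[nH]1` differs from compound 1 in one place: 4-chloro-2-methoxyphenyl in place of 2-chlorophenyl on an aromatic carbon. Among the compounds with values here, no measured step matches this change closely; the nearest are a step that the two limits leave unreadable from compound 1 to compound 2 and a step that the two limits leave unreadable from compound 1 to compound 3, and neither can be read in size, so no direction and no size beyond the scatter can be expected for a step that the limit leaves unreadable from compound 1 to compound 4. Compound 4 is therefore estimated at 1 h, within 0.5 h to 3 h, with a good chance that the assay again reports only a limit.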

Compound 4, half-life: > 0.5 h
Compound 4 ended at the assay's limit (the forecaster's own chance of this, stated with the estimate: 75%); the middle value does not contradict the limit.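

The steps from compound 4 to compounds 1, 2 and 3 cannot be read, since all four compounds give only a limit: the limit of > 0.5 h in this assay, at which 4 of the 4 values shown sit. From the compounds shown here alone, the actual half-life of each compound in this assay, and whether these phenyl groups change it, remain open.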